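Sulfonylurea series: dropping the chloro on the sulfonyl aryl

This account rests on a few compounds, and the source may have more. Where it says the series, first, only, none or still open, it means among the compounds named here.

Measured so far:
compound 1 `Cc1ccc(OCc2ccccc2)c(C(C)NC(=O)NS(=O)(=O)c2ccc(Cl)cc2)c1`: 65300 nM in a functional assay on thoracic aorta (Rattus norvegicus, strain Wistar), with a stated time of 15 min; a lower number here means that less compound is needed, a higher number that more compound is needed for the effect
compound 2 `COc1ccc(F)cc1C(C)NC(=O)NS(=O)(=O)c1ccccc1`: > 300000 nM in this assay

Among the measured compounds shown here, compound 1 carries the only number in this assay. For compound 2 the assay reports a limit and no number, namely (the limit of > 300000 nM in this assay, at which 1 of the 2 values shown sits). For the measured compounds named here, nothing measured to date isolates a single structural change, so no step size is known from the data themselves; the two entries share the sulfonylurea core but differ in several places and show only that compound 1 gave a number where compound 2 did not.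

The next compound, compound 3 `Cc1ccc(OCc2ccccc2)c(C(C)NC(=O)NS(=O)(=O)c2ccccc2)c1`, keeps the whole of compound 1 except for one point: hydrogen in place of chloro on an aromatic carbon. The change sits on the sulfonyl side, para to a large group, and is small in heavy-atom count.

The step of a 2.0-fold higher number from compound 1 to compound 3 (0.30 log units; within the scatter) is expected to be a modest loss, near the edge of the usual scatter, with a real chance that the assay returns only a limit. Compound 3 is expected to give about 130000 nM, within a range from 50000 nM to 300000 nM.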

Compound 3, half-maximal effective concentration: > 200000 nM
Compound 3: no number, only a limit; the forecaster's own chance of this, stated with the estimate: 30%; middle value at least 1.5-fold (0.18 log units) from the limit.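

Hydrogen in place of chloro on an aromatic carbon gives the first single-place comparison in the series, and in this assay it reads as an at least 3.0-fold higher number from compound 1 to compound 3 (0.48 log units; beyond the scatter). Compound 3 gives only a limit and no number, so the step has a lower bound and no upper one: the limit of > 200000 nM in this assay, at which 1 of the 3 values shown sits.

Within this pair only compound 1, which keeps the 4-chlorophenyl group, gives a number, so the position para to a large group is not indifferent to this change, at least on the benzyloxy-bearing side of the shared core.

This single pair leaves open whether the loss is specific to chloro or whether other groups at the same aromatic carbon, such as bromo or a nitrile, would also keep a measurable number in this assay. It also leaves open how large the step really is and whether it would carry over to other amine-side aryl groups, since compound 2 differs from the other two compounds in several places and gives no single-change comparison.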